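Notes on benzyl swaps: toward compound 3

The compounds below may be only part of what the source reports. "The series", "measured", "known", "first", "only" and "open" are said of these compounds alone.

- compound 1 `N#Cc1cccc(Cn2cc(CNC3=C(Cl)C(=O)c4cccnc4C3=O)nn2)c1`: 4920 nM
- compound 2 `Cc1ccc(Cn2cc(CNC3=C(Cl)C(=O)c4cccnc4C3=O)nn2)cc1`: 3920 nM

Only these two compounds have been measured so far in a functional assay on A549 cells (Homo sapiens) for antiproliferative activity, read by sulforhodamine B assay, with a stated time of 72 h; on this read-out higher numbers stand for weaker inhibition and lower numbers for stronger inhibition. Compound 2 gives 3920 nM, which lies within the scatter of compound 1 at 4920 nM, so neither can be ranked above the other.

The next compound is compound 3 `N#Cc1ccccc1Cn1cc(CNC2=C(Cl)C(=O)c3cccnc3C2=O)nn1`. It has 2-cyanophenyl in place of 4-methylphenyl on a saturated chain carbon bound to an aromatic nitrogen.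

Among the compounds with values here, one measured step bears on this change. In a 1.3-fold lower number from compound 1 to compound 2 (0.10 log units; within the scatter), 4-methylphenyl replaced 3-cyanophenyl at the same place, and the number stayed within the scatter. Within the data shown here, no measured compound yet carries 2-cyanophenyl, so this single step is a thin basis for a forecast. Given that step, no shift beyond the scatter is expected in this assay. The expected change is a 1.1-fold higher number from compound 2 to compound 3 (0.06 log units; within the scatter), and no clear direction can be assigned to it. The estimate for compound 3 is 4500 nM, with an expected range of 2000 nM to 10000 nM.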

Compound 3, half-maximal inhibitory concentration: 4500 nM
Compound 3: middle estimate and measured number agree at the digits printed, and the stated range covers the measured number.
By their numbers in this assay, from the lowest: compounds 2, 3 and 1 (each within the scatter of the next).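

In this assay, 2-cyanophenyl in place of 4-methylphenyl on a saturated chain carbon bound to an aromatic nitrogen gives a 1.1-fold higher number from compound 2 to compound 3 (0.06 log units; within the scatter), so the entering nitrile adds a hydrogen-bond acceptor by the count without a readable shift in the number. Set against the other cyano compound, 2-cyanophenyl in place of 3-cyanophenyl gives a 1.1-fold lower number from compound 1 to compound 3 (0.04 log units; within the scatter), which is the only step shown that compares two nitrile-bearing groups at this place, and it does not separate them. No measurement at hand offers any account of why these three groups cannot be told apart.

On these data alone, all three compounds still sit within the scatter of one another, so the series shows no direction at this position, and it remains open whether any group placed here can move the number beyond the scatter at all. An amine or a carboxylic acid on the phenyl ring, or a longer chain in place of the single saturated chain carbon, would test this, and the shared core stays unvaried in the compounds shown.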